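This account rests on a few compounds, and the source may have more. Where it says the series, first, only, none or still open, it means among the compounds named here.

In an assay on isolated protein for inhibition of proto-oncogene tyrosine-protein kinase receptor Ret variant V804M (Homo sapiens), read by 33P incorporation, with stated times of 15 min and 40 min (a higher number here means a weaker inhibitor, a lower number a stronger inhibitor), the three measured compounds give:
compound 1 `O=C(Nc1ccc(Br)cc1)Nc1ccc(Nc2ncnc3c2OCCN3)cc1`, 2350 nM;
compound 2 `O=C(Nc1ccc(Nc2ncnc3c2OCCN3)cc1)Nc1ccc(C(F)(F)F)cc1`, 276 nM;
compound 3 `COc1cccc(NC(=O)Nc2ccc(Nc3ncnc4c3OCCN4)cc2)c1`, 5290 nM.

Compound 2 stands lowest of the three, with steps an 8.5-fold lower number from compound 1 to compound 2 (0.93 log units; beyond the scatter) and a 19-fold higher number from compound 2 to compound 3 (1.28 log units; beyond the scatter) both beyond the scatter. Compound 4 `CC(C)(C)c1cc(NC(=O)Nc2ccc(Nc3ncnc4c3OCCN4)cc2)no1` differs from compound 2 in one place: 5-(tert-butyl)-1,2-oxazol-3-yl in place of 4-(trifluoromethyl)phenyl on an amide-type nitrogen. Among the measured compounds shown here, no measured step swaps a six-membered aromatic ring for a five-membered one on that nitrogen, so neither step bears on it directly; they show only that the group on this nitrogen moves this assay by modest to large amounts. A modest rise from compound 2 is therefore expected, a 2.0-fold higher number from compound 2 to compound 4 (0.30 log units; within the scatter). Compound 4 is estimated at 550 nM, within 110 nM to 2800 nM.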

Compound 4, half-maximal inhibitory concentration: 34 nM
Compound 4: middle estimate off by 16-fold (1.21 log units), on the high side; the measured number lies below the stated range.
By their numbers in this assay, from the lowest: compound 4; then compound 2; then compound 1; then compound 3.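

In this assay the five-membered aromatic ring with 2 hetero atoms gives an 8.1-fold lower number from compound 2 to compound 4 (0.91 log units; beyond the scatter) and also a 69-fold lower number from compound 1 to compound 4 (1.84 log units; beyond the scatter) and a 160-fold lower number from compound 3 to compound 4 (2.19 log units; beyond the scatter) on the same amide-type nitrogen. Compound 4 therefore stands lowest of the four, and this position does not need a six-membered aromatic ring of carbon only for the lowest number seen so far. Nothing measured here accounts for this drop.

The tert-butyl group and the 1,2-oxazole ring enter together, so their shares remain unseparated. A 4-(tert-butyl)phenyl or 5-methyl-1,2-oxazol-3-yl group on this nitrogen would divide them.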